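Chloro in Place of Nitro: An Expected Small Step

The source may report more compounds than this note shows. Statements on the series, on what has been measured and on what is new or still open speak of the compounds shown alone.

In a functional assay on HeLa cells (Homo sapiens) for antiproliferative activity, read by MTT assay, with a stated time of 48 h (on this read-out higher numbers stand for weaker inhibition and lower numbers for stronger inhibition), compound 1 `O=[N+]([O-])c1cccc(-c2nn(-c3ccccc3)cc2C(Nc2nc3ccccc3s2)c2c(O)ccc3ccccc23)c1` reads 8220 nM and compound 2 `Cc1ccc2nc(NC(c3cn(-c4ccccc4)nc3-c3cccc([N+](=O)[O-])c3)c3c(O)ccc4ccccc34)sc2c1` reads 7360 nM on the same scale, so these two values lie within the scatter of each other. Compound 3 `Cc1ccc2nc(NC(c3cn(-c4ccccc4)nc3-c3cccc(Cl)c3)c3c(O)ccc4ccccc34)sc2c1` differs from compound 2 in one place, with chloro in place of nitro on an aromatic carbon is the full count of that change, which turns 3-nitrophenyl into 3-chlorophenyl. Among the compounds with values here, the only measured step is a 1.1-fold lower number from compound 1 to compound 2 (0.05 log units; within the scatter) for methyl in place of hydrogen, a different change, so it gives neither size nor direction for this swap. Within the data shown here, no chloro compound has been measured yet. Nothing beyond the scatter is therefore expected in this assay with any confidence, and the range must stay wide. For compound 3 the expected value is 6500 nM with an estimated range of 2500 nM to 17000 nM for now. That estimate means a 1.1-fold lower number from compound 2 to compound 3 (0.05 log units; within the scatter) as the expected step.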

Compound 3, half-maximal inhibitory concentration: 9430 nM
Estimate against measurement, compound 3: 1.5-fold (0.16 log units) below; low and high end bracket the measured number.
By their numbers in this assay, from the lowest: compounds 2, 1 and 3 (each within the scatter of the next).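

Replacing the nitro group with a chloro group gives a 1.3-fold higher number from compound 2 to compound 3 (0.11 log units; within the scatter). In this assay, then, the 3-nitrophenyl group can give way to 3-chlorophenyl without a difference that can be told from the scatter, even though a group with 3 heavy atoms and 2 hydrogen-bond acceptors is replaced by one with 1 heavy atom and no hydrogen-bond acceptors. Within the data shown here, the earlier step concerned a methyl group elsewhere on the molecule, so this is the first reading of a change at this place on the ring, and no measurement is available to explain the result.

Going by these compounds, whether an amine or a carboxylic acid at this same place would move the number beyond the scatter remains open. Also open, on these data alone, is whether chloro in place of nitro would read the same without the methyl group of compound 2, as in compound 1.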